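Trimming the Amide Substituent Down to a Hydroxy Group

A few compounds are considered here, and "the series" means these few. Any claim that something is new, unique, unknown or untested is made for them only; others in the source may bear on it.

Measured so far:
compound 1 `C=C(CC)C(=O)c1ccc(OCC(=O)Nc2ccc3nc[nH]c3c2)c(Cl)c1Cl` gives 3200 nM
compound 2 `C=C(CC)C(=O)c1ccc(OCC(=O)Nc2ccc3c(c2)C(O)N=NC3O)c(Cl)c1Cl` gives 8500 nM
compound 3 `C=C(CC)C(=O)c1ccc(OCC(=O)Nc2ccc3cc(C(=O)O)ccc3c2)c(Cl)c1Cl` gives 3700 nM

All three were tested in a functional assay on CLL cells (Homo sapiens) for cytotoxicity, read by MTT assay, with a stated time of 48 h; a lower number here means that less compound is needed, a higher number that more compound is needed for the effect. Compound 1 stands at the lowest number of the three; compound 3 lies within the usual scatter of it, while compound 2 sits beyond the scatter at a higher number. Among the compounds with values here, no two measured compounds differ in only one place, so no single step can be read off. Compound 4 `C=C(CC)C(=O)c1ccc(OCC(=O)NO)c(Cl)c1Cl` is not yet measured. It differs from compound 1 as follows: hydroxy in place of 1H-benzimidazol-6-yl on an amide-type nitrogen. Swapping the 1H-benzimidazol-6-yl group for hydroxy is a considerable change, yet the measured values cluster closely. The step of a 1.9-fold higher number from compound 1 to compound 4 (0.27 log units; within the scatter) is expected to be small and toward a higher number, perhaps within the scatter. Compound 4 is expected to give about 6000 nM, between 2000 nM and 20000 nM.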

Compound 4, half-maximal effective concentration: 4500 nM
For compound 4 the middle estimate is 1.3-fold (0.12 log units) above the measured one, and the stated range covers the measured number.
By their numbers in this assay, from the lowest: compounds 1, 3, 4 and 2 (each within the scatter of the next, the first and the last beyond it).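

Replacing 1H-benzimidazol-6-yl with hydroxy on the amide-type nitrogen gives a 1.4-fold higher number from compound 1 to compound 4 (0.15 log units; within the scatter) in this assay, so at this position the result does not depend on keeping the two aromatic rings of that group. The earlier compounds shown here could not show this, since none of them lacked a ring system at this position. Nothing available explains why the two numbers lie so close. Still open, from the compounds shown here alone, is how a methoxy group, an amino group or a longer carbon chain on this nitrogen would read.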